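Naphthalen-1-yl in place of 3-methylphenyl on the shared core

The compounds below may be only part of what the source reports. "The series", "measured", "known", "first", "only" and "open" are said of these compounds alone.

Compound 3 `Cc1cccc(-c2cn3ccnc3c(-c3ccc4ncn(Cc5ccccc5)c4c3)n2)c1` gives 22.1% in a functional assay on A498 cells (Homo sapiens) for inhibition, read by sulforhodamine B assay, with a stated time of 48 h, tested at 10 uM (on this read-out higher numbers stand for more inhibition at the one concentration tested (going by the name of the read-out) and lower numbers for less inhibition), the highest of the three numbers; compound 2 `Brc1ccc(-c2cn3ccnc3c(-c3ccc4ncn(C5CCCCC5)c4c3)n2)cc1` sits within the scatter of it at 20.7%, whereas compound 1 `COc1ccc(-c2cn3ccnc3c(-c3ccc4ncn(C5CCCCC5)c4c3)n2)cc1` lies far lower at -12.3%. Going by the values given here, the only step between compounds that differ in one place is a number 33 percentage points higher from compound 1 to compound 2 (beyond the scatter). Compound 4 `c1ccc(Cn2cnc3ccc(-c4nc(-c5cccc6ccccc56)cn5ccnc45)cc32)cc1` is not yet measured; it differs from compound 3 in that (naphthalen-1-yl in place of 3-methylphenyl on an aromatic carbon). Among the compounds with values here, no measured step concerns this change, and the one step that exists touches a different group, so there is nothing on which to base an expectation beyond the scatter. The estimate for compound 4 is therefore 25%, between 3% and 47%, a step of a number 2.9 percentage points higher from compound 3 to compound 4 (within the scatter).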

Compound 4, a percentage reported as inhibition, at one concentration (the size of the read-out at that concentration, not a potency): 6.74%
The estimate for compound 4 lay 18.3 percentage points above the measured number, within the range that was stated.
By their numbers in this assay, from the lowest: compound 1; then compound 4; then compounds 2 and 3 (each within the scatter of the next).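

At this aromatic carbon of the shared core, in this assay, naphthalen-1-yl in place of 3-methylphenyl gives a number 15.4 percentage points lower from compound 3 to compound 4 (beyond the scatter), so replacing the whole aryl group here moves the number beyond the scatter. Two six-membered aromatic rings at this carbon therefore do not add inhibition over one ring bearing methyl. Nothing available explains this step.

The compounds shown leave open how a group carrying an amine or a carboxylic acid would fare at this carbon. They also leave open whether the step holds with the ring substituent that compound 1 and compound 2 carry on the core.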